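This account rests on a few compounds, and the source may have more. Where it says the series, first, only, none or still open, it means among the compounds named here.

Compound 1 `C=c1[nH]c(=O)/c(=C/c2ccc(OC)cc2)[nH]c1=O` and compound 2 `C=c1[nH]c(=O)/c(=C/c2ccc(N(C)C)cc2)[nH]c1=O` share one core and differ in a single group. In a functional assay on Huh7.5.1 cells (Homo sapiens) for cytotoxicity, read by MTT assay, with a stated time of 72 h (on this read-out lower numbers stand for higher toxicity in this test and higher numbers for lower toxicity in this test), compound 1 gives > 20000 nM, which is a limit of the assay and not a number. Compound 2 gives > 20000 nM, again only a limit. Compound 2 therefore has no number to stand on, only (the limit of > 20000 nM in this assay, at which 2 of the 2 values shown sit). Among the measured compounds shown here, the one measured change is a step that the two limits leave unreadable from compound 1 to compound 2, so no size can be carried forward from it. Compound 3 `C=c1[nH]c(=O)/c(=C/c2ccc(C(F)(F)F)cc2)[nH]c1=O` keeps the shared core and brings a new group to the same place, with trifluoromethyl in place of dimethylamino on an aromatic carbon. For the measured compounds named here, compound 2 offers only the limit > 20000 nM as a starting point, so no marked step toward higher toxicity is expected in this assay. The expected change is a step that the limit leaves unreadable from compound 2 to compound 3. For compound 3 the estimate is 25000 nM, with an expected range from 10000 nM to 60000 nM.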

Compound 3, half-maximal cytotoxic concentration: > 20000 nM
Compound 3: a limit, no number; the forecaster's own chance of this, stated with the estimate: 80%; the middle value does not contradict the limit.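

Compound 3, like compound 1 and compound 2, gives only a limit and not a number in this assay, so no step among these compounds can be read. The compounds shown leave open whether changing this group affects toxicity in this assay at all: the limit of > 20000 nM in this assay, at which 3 of the 3 values shown sit.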